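This account rests on a few compounds, and the source may have more. Where it says the series, first, only, none or still open, it means among the compounds named here.

Measured so far:
Compound 1, `CCNCc1ccc(N/C(=C2\C(=O)Nc3cc(C(=O)N(C)CC)ccc32)c2ccccc2)cc1`, gives 78% in an assay on isolated protein for inhibition of tyrosine-protein kinase CSK (Homo sapiens), tested at 1 uM; a lower number here means less inhibition, a higher number more inhibition at the concentration tested (going by the name of the read-out).
Compound 2, `CN(C)C(=O)c1ccc2c(c1)/C(=C(/Nc1ccc(CN3CCCCC3)cc1)c1ccccc1)C(=O)N2`, gives 74% in this assay.
Compound 3, `CCNC(=O)c1ccc2c(c1)NC(=O)/C2=C(\Nc1ccc(CN(C)C)cc1)c1ccccc1`, gives 96% in this assay.

Compound 2 stands lowest of the three numbers. Compound 1 lies within the usual scatter of it, so the two cannot be told apart; compound 3 lies beyond the scatter above it. Compound 4, `O=C1Nc2ccccc2/C1=C(/Nc1ccc(CN2CCCCC2)cc1)c1ccccc1`, differs from compound 2 in one place: hydrogen in place of dimethylcarbamoyl on an aromatic carbon. Within the data shown here, all three measured compounds carry a carboxamide on the shared core, so no measured pair shows what its removal does. A drop in this assay beyond the scatter is expected, of the size a number 19 percentage points lower from compound 2 to compound 4 (beyond the scatter). Compound 4 is thus estimated at 55%, with a range from 25% to 80%.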

Compound 4, a percentage reported as inhibition, at one concentration (the size of the read-out at that concentration, not a potency): 32%
Compound 4: middle estimate off by 23 percentage points, on the high side; the measured number falls inside the stated range.
By their numbers in this assay, from the lowest: compound 4; then compounds 2 and 1 (each within the scatter of the next); then compound 3.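

Among these compounds, replacing dimethylcarbamoyl with hydrogen on this aromatic carbon gives, in this assay, a number 42 percentage points lower from compound 2 to compound 4 (beyond the scatter), the first change at this position that can be read on its own. The carboxamide place on the shared core therefore matters for inhibition at the concentration tested, at least with the piperidinylmethyl side chain of compound 2 and compound 4. Nothing measured here explains the drop. Still open, as far as these compounds go, is whether a carboxylic acid, a primary amine or a simple methyl on this carbon would recover the lost inhibition. From the compounds shown here alone, whether the same removal costs as much with another side chain also remains open.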